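The source may hold more compounds than are shown below. What is called first, only, known or untested is meant among the compounds shown, and "the series" means these compounds.

In an assay on CHO-K1 cells for displacement of a labelled ligand from prostaglandin E2 receptor EP1 subtype (Homo sapiens) (on this read-out lower numbers stand for stronger inhibition and higher numbers for weaker inhibition), compound 1 `Cc1cc(NC(=O)OC(C)(C)C)nn1Cc1cc(Cl)ccc1OCC(C)C` gives 31.6 nM. Compound 2 `Cc1cc(NC(=O)OC(C)(C)C(F)(F)F)nn1Cc1cc(Cl)ccc1OCC(C)C` gives 50.1 nM in this assay, and the step of a 1.6-fold higher number from compound 1 to compound 2 (0.20 log units; within the scatter) lies within the scatter, so compound 2 stands alongside compound 1 with no separable difference between them. Compound 3 `Cc1cc(NC(=O)OC2CCOCC2)nn1Cc1cc(Cl)ccc1OCC(C)C` differs from compound 2 by oxan-4-yl in place of 1-methyl-1-(trifluoromethyl)ethyl on an oxygen next to a carbonyl group. For the measured compounds named here, the only measured step sat on that same oxygen but swapped methyl for trifluoromethyl, whereas here the whole group is exchanged for a ring; it gives little guidance, and the expected step is a 1.0-fold lower number from compound 2 to compound 3 (0.00 log units; within the scatter), nothing beyond the scatter. Compound 3 is therefore estimated at 50 nM, between 15 nM and 170 nM.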

Compound 3, half-maximal inhibitory concentration in the prostaglandin E2 receptor EP1 subtype assay: 63.1 nM
Beside the measured number, compound 3's estimate is 1.3-fold (0.10 log units) below it, and the stated range covers the measured number.
By their numbers in the prostaglandin E2 receptor EP1 subtype assay, from the lowest: compounds 1, 2 and 3 (each within the scatter of the next).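

In the prostaglandin E2 receptor EP1 subtype assay compound 3 gives 63.1 nM, and the ring oxan-4-yl on an oxygen next to a carbonyl group cannot be told apart from the two groups without a ring, with a 1.3-fold higher number from compound 2 to compound 3 (0.10 log units; within the scatter) and a 2.0-fold higher number from compound 1 to compound 3 (0.30 log units; within the scatter) as the steps from 1-methyl-1-(trifluoromethyl)ethyl and tert-butyl. In a physicochemical assay for lipophilicity, at pH 7.4 (a higher number here means a more lipophilic compound, a lower number a more polar compound), compound 2 gives 3.5 and compound 3 gives 3.4; the exchange gives a number 0.10 log units lower from compound 2 to compound 3 (within the scatter) and again separates nothing. Nothing shown explains why these groups read alike. On these data alone, whether an amine or a carboxylic acid on this oxygen would also be tolerated stays open, as does the effect of a longer chain there.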